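The source may report more compounds than this note shows. Statements on the series, on what has been measured and on what is new or still open speak of the compounds shown alone.

Measured so far in a functional assay on OVCAR-3 cells (Homo sapiens) for antiproliferative activity, read by MTT assay, with a stated time of 24 h; a lower number here means a stronger inhibitor, a higher number a weaker inhibitor: compound 1 `O=c1[nH]cc(S(=O)(=O)Nc2ccc(-c3cn(-c4ccccc4)nn3)cc2)c(=O)[nH]1` gives 18000 nM; compound 2 `Cc1ccc(-n2cc(-c3ccc(NS(=O)(=O)c4c[nH]c(=O)[nH]c4=O)cc3)nn2)cc1` gives 5630 nM.

Compound 2 stands lowest of the two numbers. Among the measured compounds shown here, the single measured step, a 3.2-fold lower number from compound 1 to compound 2 (0.50 log units; beyond the scatter), is the only one that bears on the next change: compound 3 `O=c1[nH]cc(S(=O)(=O)Nc2ccc(-c3cn(-c4cccc(F)c4)nn3)cc2)c(=O)[nH]1` carries 3-fluorophenyl in place of 4-methylphenyl on an aromatic nitrogen. For the measured compounds named here, the methyl that set compound 2 apart from compound 1 leaves and a fluorine arrives on a different position of the same ring; no measured step covers a fluorine on that ring. A number between the two measured ones is expected, closer to compound 1, so a modest rise in this assay, a 2.0-fold higher number from compound 2 to compound 3 (0.29 log units; within the scatter). Compound 3 is estimated at 11000 nM, range 4000 nM to 30000 nM.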

Compound 3, half-maximal inhibitory concentration: > 20000 nM
Compound 3 gave a limit, no number (the forecaster's own chance of this, stated with the estimate: 5%); at least 1.8-fold (0.25 log units) between middle value and limit.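

In this assay compound 3 returns a limit, not a number: the limit of > 20000 nM in this assay, at which 1 of the 3 values shown sits.

Replacing 4-methylphenyl with 3-fluorophenyl on the aromatic nitrogen gives an at least 3.5-fold higher number from compound 2 to compound 3 (0.55 log units; beyond the scatter), so the lower number seen with the methyl does not carry over to this group. The added fluorine on its own gives an at least 1.1-fold higher number from compound 1 to compound 3 (0.04 log units; that floor lies within the scatter), so this fluorine brings no lowering of the number.

As far as these compounds go, whether the lower number of compound 2 depends on the methyl itself or on its ring position remains open. From the compounds shown here alone, how a methoxy or an amine on that ring would read also remains open.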